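Two Ring Substituents Measured, a Third Awaiting Its Number

The source may hold more compounds than are shown below. What is called first, only, known or untested is meant among the compounds shown, and "the series" means these compounds.

Compound 1 `CC(C)=CCC[C@]1(C)/C=C/[C@@H](OC(=O)C=C(C)C)[C@](C)(O)/C=C/C(=O)/C(CN(C(C)C)C(C)C)=C\C1` is a carbocyclic macrolide-like structure carrying a (diisopropylamino)methyl group on a double-bonded ring carbon. In a functional assay on MCF7 cells (Homo sapiens) for antiproliferative activity, read by MTT assay, with a stated time of 48 h (on this read-out lower numbers stand for stronger inhibition and higher numbers for weaker inhibition), compound 1 gives 780 nM, the lower of the two numbers recorded so far. Its companion, compound 2 `CC(C)=CCC[C@]1(C)/C=C/[C@@H](OC(=O)C=C(C)C)[C@](C)(O)/C=C/C(=O)/C(C[Si](c2ccccc2)(c2ccccc2)C(C)(C)C)=C\C1`, bears a silyl-based substituent at the same position, and in this assay compound 2 gives 15800 nM, a gap from compound 1 that lies well beyond the scatter of repeated measurements.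

The unmeasured compound 3 `CCN(CC)C(=O)/C1=C/C[C@](C)(CCC=C(C)C)/C=C/[C@@H](OC(=O)C=C(C)C)[C@](C)(O)/C=C/C1=O` keeps the shared core of compound 1 and changes only the ring substituent: diethylcarbamoyl in place of (diisopropylamino)methyl on a double-bonded ring carbon. For the measured compounds named here, no step between two measured compounds isolates this exact change, so any expectation rests on the two numbers above alone.

Going by the values given here, since the only comparison available shows a very different substituent weakening inhibition markedly, compound 3 is expected to shift modestly in the same direction, with an estimated step of a 2.6-fold higher number from compound 1 to compound 3 (0.41 log units; beyond the scatter) in this assay. Compound 3 is therefore estimated at 2000 nM, within a range of 500 nM to 8000 nM.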

Compound 3, half-maximal inhibitory concentration: 12100 nM
Compound 3: the middle estimate sits 6.1-fold (0.78 log units) below what was measured; the whole stated range lies below it.
By their numbers in this assay, from the lowest: compound 1; then compounds 3 and 2 (each within the scatter of the next).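

In this assay, putting diethylcarbamoyl in place of (diisopropylamino)methyl on the double-bonded ring carbon is a large step, a 16-fold higher number from compound 1 to compound 3 (1.19 log units; beyond the scatter), so this position does not accept every replacement alike, although the entering group has 7 heavy atoms against 8 and the same counts of hydrogen-bond donors and acceptors. The earlier pair could have left the weaker number looking like a feature of the silyl-based substituent alone, but compound 3 and compound 2 now stand within the scatter of each other, and compound 1 alone stands apart from both with the lowest number. Nothing measured on these compounds accounts for the size of this step.

The compounds shown leave open whether the lower number of compound 1 goes with an amine joined to the ring through a single carbon, which a (dimethylamino)methyl or a morpholinomethyl group at the same ring carbon would test. They also leave open whether the isopropyl groups matter, which a diisopropylcarbamoyl or a (diethylamino)methyl group would help separate from the change at the carbonyl.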